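Compound 2 to compound 3: one aromatic group exchanged

This account rests on a few compounds, and the source may have more. Where it says the series, first, only, none or still open, it means among the compounds named here.

compound 1 `O=C(CCCCCCc1nc(-c2ccc(F)cc2)no1)NO`: 5770 nM
compound 2 `O=C(CCCCCCc1nc(-c2cccs2)no1)NO`: 4370 nM

Both values come from a functional assay on A549 cells (Homo sapiens) for antiproliferative activity, read by MTT assay, with a stated time of 72 h; on this read-out higher numbers stand for weaker inhibition and lower numbers for stronger inhibition. Among the compounds with values here, compound 2, at 4370 nM, lies within the scatter of compound 1, and these two are the only numbers so far. Compound 3 `O=C(CCCCCCc1nc(-c2cccnc2)no1)NO` is not yet measured. It carries pyridin-3-yl in place of thiophen-2-yl on an aromatic carbon, between two ring nitrogen atoms: pyridin-3-yl in place of thiophen-2-yl on an aromatic carbon. Within the data shown here, the one measured exchange at this place, a 1.3-fold lower number from compound 1 to compound 2 (0.12 log units; within the scatter), bears directly on it and stays within the scatter. Among the measured compounds shown here, no measured compound carries pyridin-3-yl, so that single step is the only guide. No step beyond the scatter is expected in this assay, and no direction can be read from the data. The estimated change is a 1.1-fold higher number from compound 2 to compound 3 (0.06 log units; within the scatter). For compound 3 the estimated value is 5000 nM, with an expected range of 2000 nM to 12000 nM.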

Compound 3, half-maximal inhibitory concentration: 5340 nM
Compound 3: middle estimate off by 1.1-fold (0.03 log units), on the low side, within the range that was stated.
By their numbers in this assay, from the lowest: compounds 2, 3 and 1 (each within the scatter of the next).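

In this assay pyridin-3-yl gives a 1.2-fold higher number from compound 2 to compound 3 (0.09 log units; within the scatter) and a 1.1-fold lower number from compound 1 to compound 3 (0.03 log units; within the scatter) as the two new steps at this place, both within the scatter. On the shared core, the aromatic carbon between two ring nitrogen atoms now carries a six-membered aromatic ring with a ring nitrogen, a five-membered aromatic ring with sulfur, or 4-fluorophenyl, and none of these exchanges separates the three compounds. No supporting data are available for interpreting this result.

The compounds shown leave open whether an amine, a carboxylic acid or a methyl group at this place would give a step beyond the scatter. They also leave open whether a longer chain on the shared core would change the number in this cell line.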